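Swapping ethyl for pyridin-2-yl on the amino nitrogen

A few compounds are considered here, and "the series" means these few. Any claim that something is new, unique, unknown or untested is made for them only; others in the source may bear on it.

For the measured compounds named here, only two compounds of this kind have numbers so far. In a functional assay on SF-268 cells (Homo sapiens) for cytotoxicity, read by MTT assay, with a stated time of 3 days (a lower number here means a stronger inhibitor, a higher number a weaker inhibitor), compound 1 (`N#Cc1c(O)nc(SCc2nc3ccccc3[nH]2)nc1-c1ccccc1`) gives 3.2 nM, and compound 2 (`CCNc1nc(SCc2nc3ccccc3[nH]2)nc(-c2ccccc2)c1C#N`) gives 7.35 nM, the higher of the two numbers and so the weaker inhibitor. The unmeasured compound 3 (`N#Cc1c(Nc2ccccn2)nc(SCc2nc3ccccc3[nH]2)nc1-c1ccccc1`) keeps the shared core and changes one group: pyridin-2-yl in place of ethyl on a nitrogen on an aromatic ring, which turns ethylamino into (pyridin-2-yl)amino (pyridin-2-yl in place of ethyl on a nitrogen on an aromatic ring). Going by the values given here, one measured step bears on this, a 2.3-fold higher number from compound 1 to compound 2 (0.36 log units; beyond the scatter), in which ethylamino stands in place of hydroxy. That step was modest, but it is a different change, so it offers only a rough sense of scale. Among the compounds with values here, no measurement yet shows what a ring on this nitrogen does. In this assay, a small step that stays within the scatter is therefore expected: a 1.2-fold higher number from compound 2 to compound 3 (0.09 log units; within the scatter). The estimate for compound 3 is 9 nM, with an expected range from 2.5 nM to 30 nM.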

Compound 3, half-maximal inhibitory concentration: 6.75 nM
Beside the measured number, compound 3's estimate is 1.3-fold (0.12 log units) above it; low and high end bracket the measured number.
By their numbers in this assay, from the lowest: compound 1; then compounds 3 and 2 (each within the scatter of the next).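

In this assay, the nitrogen on the aromatic ring takes pyridin-2-yl, a six-membered aromatic ring of 6 heavy atoms, in place of the 2-carbon ethyl, and the result is a 1.1-fold lower number from compound 2 to compound 3 (0.04 log units; within the scatter), so the two compounds cannot be told apart in this assay despite the much larger group. The comparison with hydroxy gives a 2.1-fold higher number from compound 1 to compound 3 (0.32 log units; beyond the scatter), a modest step that lies beyond the scatter and is close in size to a 2.3-fold higher number from compound 1 to compound 2 (0.36 log units; beyond the scatter), so for the two amino groups shown, ethylamino and (pyridin-2-yl)amino, the number is higher than with hydroxy. Nothing in the available data offers a reason for either of these results.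

The compounds shown leave open whether the same holds for other groups on this nitrogen, such as a plain phenyl ring, which would show whether the nitrogen of the pyridin-2-yl ring matters, or a longer chain such as butyl. A bare amino group, with nothing on the nitrogen, would also show whether any group is needed there at all.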